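The compounds below may be only part of what the source reports. "The series", "measured", "known", "first", "only" and "open" are said of these compounds alone.

In a functional assay on MCF7 cells (Homo sapiens) for cytotoxicity, read by MTT assay, with a stated time of 96 h (on this read-out lower numbers stand for stronger inhibition and higher numbers for weaker inhibition), the measured compounds are:

- compound 1 `COc1cc(C(=O)c2cn(-c3cccc(C)c3)cc2-c2ccccc2Cl)cc(OC)c1OC`: 420 nM
- compound 2 `COc1cc(C(=O)c2cn(-c3cccc(C)c3)cc2-c2ccccc2[N+](=O)[O-])cc(OC)c1OC`: 220 nM
- compound 3 `COc1cc(C(=O)c2cn(-c3cccc(C)c3)cc2-c2cccc([N+](=O)[O-])c2)cc(OC)c1OC`: 880 nM

Compound 3 has the highest number of the three. Compound 4 `COc1cc(C(=O)c2cn(-c3ccc(F)cc3)cc2-c2cccc([N+](=O)[O-])c2)cc(OC)c1OC` differs from it by 4-fluorophenyl in place of 3-methylphenyl on an aromatic nitrogen, with 4-fluorophenyl in place of 3-methylphenyl on an aromatic nitrogen. Among the compounds with values here, compound 1, compound 2 and compound 3 all carry 3-methylphenyl there, so no measured step tests this change directly. The measured steps all lie on an aromatic carbon: a 1.9-fold lower number from compound 1 to compound 2 (0.28 log units; within the scatter), a 2.1-fold higher number from compound 1 to compound 3 (0.32 log units; beyond the scatter) and a 4.0-fold higher number from compound 2 to compound 3 (0.60 log units; beyond the scatter). They offer only a rough guide to size and none to direction. In this assay, the expected result is therefore no clear shift, and the estimated step is a 1.1-fold lower number from compound 3 to compound 4 (0.04 log units; within the scatter). For compound 4 the estimate is 800 nM, with an expected range from 250 nM to 2500 nM.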

Compound 4, half-maximal inhibitory concentration: 440 nM
For compound 4 the middle estimate is 1.8-fold (0.26 log units) above the measured one, within the range that was stated.
By their numbers in this assay, from the lowest: compounds 2, 1, 4 and 3 (each within the scatter of the next, the first and the last beyond it).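

Within the data shown here, this is the first measured step on the aromatic nitrogen: in this assay, 4-fluorophenyl in place of 3-methylphenyl gives a 2.0-fold lower number from compound 3 to compound 4 (0.30 log units; within the scatter), which lies within the scatter. With the 3-nitrophenyl group held fixed, this single exchange of two aryl groups of equal heavy-atom count therefore shows no clear shift. Nothing available explains this result.

Still open, going by these compounds, is whether the same exchange would read alike with the 2-nitrophenyl or 2-chlorophenyl group in place. On these data alone, it is also open how a benzyl group or a longer alkyl chain on that nitrogen would read.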